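Replacing the oxopiperazine of compound 2 with an ethylpiperazine

The source may hold more compounds than are shown below. What is called first, only, known or untested is meant among the compounds shown, and "the series" means these compounds.

Measured so far in an assay on HEK293 cells for inhibition of acid ceramidase (Homo sapiens), read by fluorescence, with stated times of 10 min and 3 h; a lower number here means a stronger inhibitor, a higher number a weaker inhibitor:
compound 1 `CC(C)CNC(=O)n1c(=O)oc2ccc(C3CCN(C)CC3)cc21` gives 295 nM
compound 2 `CN1CCN(c2ccc3c(c2)oc(=O)n3C(=O)NCCCCc2ccccc2)CC1=O` gives 92 nM
compound 3 `CC(C)CNC(=O)n1c(=O)oc2cc(C3CCCN(C)C3)ccc21` gives 1750 nM

Compound 2 holds the lowest of the three numbers in this assay; compound 1 stands nearest with a higher number beyond the scatter, and compound 3 stands furthest, also beyond the scatter. Compound 4 `CCN1CCN(c2ccc3c(c2)oc(=O)n3C(=O)NCCCCc2ccccc2)CC1` is not yet measured. It differs from compound 2 in one place: 4-ethylpiperazin-1-yl in place of 4-methyl-3-oxopiperazin-1-yl on an aromatic carbon. No measured pair shows this change, so the shown values give no direct guide to its size. The step from compound 2 to compound 4 in this assay is expected to be small, in no direction beyond the scatter, with a 1.3-fold higher number from compound 2 to compound 4 (0.12 log units; within the scatter). Compound 4 is therefore estimated at 120 nM, with a range from 40 nM to 360 nM.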

Compound 4, half-maximal inhibitory concentration: 56 nM
Estimate against measurement, compound 4: 2.1-fold (0.33 log units) above, within the range that was stated.
By their numbers in this assay, from the lowest: compounds 4 and 2 (each within the scatter of the next); then compound 1; then compound 3.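

In this assay, the exchange of 4-methyl-3-oxopiperazin-1-yl for 4-ethylpiperazin-1-yl gives a 1.6-fold lower number from compound 2 to compound 4 (0.22 log units; within the scatter). This is the only pair shown that differs in one place, and it indicates that this aromatic carbon accepts either ring without a readable difference, with or without the ring carbonyl. No measurement shown offers an explanation for this.

The compounds shown leave open whether a morpholine or a carboxylic acid at this place would stay in the same range. They also leave open whether the same exchange would read alike on the core of compound 1.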